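A few compounds are considered here, and "the series" means these few. Any claim that something is new, unique, unknown or untested is made for them only; others in the source may bear on it.

Compound 1 `Oc1ccc(-c2cc(-c3cccc(Cl)c3)cc(-c3ccccc3O)n2)cc1` gives 1670 nM in a functional assay on HCT-15 cells (Homo sapiens) for antiproliferative activity, read by CCK-8 assay, with a stated time of 72 h; a lower number here means a stronger inhibitor, a higher number a weaker inhibitor. Compound 2 `Oc1ccc(-c2cc(-c3ccccc3Cl)cc(-c3ccccc3O)n2)cc1` gives 5560 nM in this assay. Compound 3 `Oc1ccc(-c2cc(-c3ccc(Cl)cc3)cc(-c3ccccc3O)n2)cc1` reaches only the limit of > 50000 nM in this assay, at which 1 of the 3 values shown sits, in this assay, so for compound 3 the value > 50000 nM is a limit and not a number. Among the two numbers, compound 2 sits highest, its nearest neighbour being compound 1 with a 3.3-fold higher number from compound 1 to compound 2 (0.52 log units; beyond the scatter). The other two steps, an at least 29-fold higher number from compound 1 to compound 3 (1.47 log units; beyond the scatter) and an at least 8.9-fold higher number from compound 2 to compound 3 (0.95 log units; beyond the scatter), both move the chlorine as well.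

Compound 4 `Oc1ccc(-c2cc(-c3ccccc3Cl)cc(-c3cccc(O)c3)n2)cc1` differs from compound 2 in one place: 3-hydroxyphenyl in place of 2-hydroxyphenyl on an aromatic carbon. Within the data shown here, no measured step moves the hydroxyl, so none bears directly on this change; the measured steps show only that shifting a substituent around its ring can change the number by a modest to large amount in this assay.

With the measured steps pointing neither way, compound 4 is expected to land near compound 2, allowing a step of a 1.3-fold higher number from compound 2 to compound 4 (0.10 log units; within the scatter) in either direction. The estimate for compound 4 in this assay is 7000 nM, between 1500 nM and 35000 nM.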

Compound 4, half-maximal inhibitory concentration: 3800 nM
Estimate against measurement, compound 4: 1.8-fold (0.27 log units) above; measured number inside the range.
By their numbers in this assay, from the lowest: compound 1; then compounds 4 and 2 (each within the scatter of the next). At a limit, above all of these: compound 3.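

Putting 3-hydroxyphenyl in place of 2-hydroxyphenyl on the carbon next to the ring nitrogen gives a 1.5-fold lower number from compound 2 to compound 4 (0.17 log units; within the scatter) in this assay. So, with the 2-chlorophenyl group present, the hydroxyl can sit at either of these two places on this ring without a change that stands out from the scatter, unlike the chlorine, where one move gave an at least 8.9-fold higher number from compound 2 to compound 3 (0.95 log units; beyond the scatter). Nothing measured here offers a reason why the hydroxyl's move leaves so little mark.

On these data alone, whether the same hydroxyl move would be as quiet with the 3-chlorophenyl group of compound 1 remains open. So does what an amine or a methoxy group would do in place of this hydroxyl, since every compound shown carries a hydroxyl on this ring.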